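The source may hold more compounds than are shown below. What is called first, only, known or untested is meant among the compounds shown, and "the series" means these compounds.

Measured compounds: compound 1 `COC(=O)c1c(N)sc(-c2ccc(Cl)cc2)c1-c1ccc(Cl)cc1` with 2780 nM, and compound 2 `Nc1sc(-c2ccc(Cl)cc2)c(-c2ccc(Cl)cc2)c1C(=O)NC1CCCCC1` with 7300 nM, both in a functional assay on PC-3 cells (Homo sapiens) for cytotoxicity, read by sulforhodamine B assay, with a stated time of 72 h; a higher number here means a weaker inhibitor, a lower number a stronger inhibitor.

On these two numbers compound 2 stands highest; its nearest neighbour is compound 1, and the step of a 2.6-fold higher number from compound 1 to compound 2 (0.42 log units; beyond the scatter), cyclohexylamino in place of methoxy on a carbonyl carbon, lies beyond the scatter. Compound 3 `Nc1sc(-c2ccc(Cl)cc2)c(-c2ccc(Cl)cc2)c1C(=S)NC1CC1` has not yet been measured. It differs from compound 2 by a group of 6 heavy atoms (4 carbon, 1 nitrogen, 1 sulfur; one three-membered non-aromatic ring of carbon only) in place of a group of 9 heavy atoms (7 carbon, 1 nitrogen, 1 oxygen; one six-membered non-aromatic ring of carbon only), on an aromatic carbon. Going by the values given here, no measured step bears directly on this change: the one known step alters the group on the carbonyl carbon, whereas here the carbonyl oxygen gives way to sulfur and the six-membered ring to a three-membered one. The shared core is unchanged. With nothing to point either way, compound 3 is expected to stay close to compound 2, at 5500 nM within 1800 nM to 17000 nM, a step of a 1.3-fold lower number from compound 2 to compound 3 (0.12 log units; within the scatter) that is estimated to remain within the scatter.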

Compound 3, half-maximal inhibitory concentration: 22100 nM
Estimate against measurement, compound 3: 4.0-fold (0.60 log units) below, outside the stated range (above it).
By their numbers in this assay, from the lowest: compound 1; then compound 2; then compound 3.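

In this assay, putting the sulfur-bearing group with its three-membered carbon ring in place of cyclohexylcarbamoyl gives a 3.0-fold higher number from compound 2 to compound 3 (0.48 log units; beyond the scatter) and so shows that this position on the shared core tolerates a further rise in the number, not only the smaller rise seen earlier. Measured against the methyl ester of compound 1, the same group gives a 7.9-fold higher number from compound 1 to compound 3 (0.90 log units; beyond the scatter), the widest gap among the three compounds. Nothing measured here accounts for this rise.

The step to compound 3 exchanges the carbonyl oxygen for sulfur and the six-membered ring for a three-membered one together, so the compounds shown cannot divide the rise between these two changes. On these data alone, what a cyclopropylcarbamoyl group would give at this position stays open, as does the result for a carboxylic acid there.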